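Isopentyl in place of cyclopentyl on the shared core

A few compounds are considered here, and "the series" means these few. Any claim that something is new, unique, unknown or untested is made for them only; others in the source may bear on it.

The study follows the step from compound 2 to compound 3. Within the data shown here, compound 2 `CC(C)CCn1nc(C2CCCC2)c(O)c(C2=NS(=O)(=O)c3cc(NS(C)(=O)=O)ccc3N2)c1=O` was measured in an in vitro ADME assay on microsomes from liver (Homo sapiens) for metabolic stability, tested at 5 uM (a lower number here means that the compound disappears faster, a higher number that the compound lasts longer), and gives 0.283 h there, the only plain number in the set. Compound 1 `CC(C)CCn1nc(-c2cccs2)c(O)c(C2=NS(=O)(=O)c3cc(NS(=O)(=O)C4CC4)ccc3N2)c1=O` reports only a limit, > 1 h in this assay, so it sits at the limit of > 1 h in this assay, at which 1 of the 2 values shown sits, and offers no number to compare. Compound 3 `CC(C)CCc1nn(CCC(C)C)c(=O)c(C2=NS(=O)(=O)c3cc(NS(C)(=O)=O)ccc3N2)c1O` has not yet been measured in this assay. It differs from compound 2 in one place: isopentyl in place of cyclopentyl on an aromatic carbon. Among the measured compounds shown here, no step between two measured compounds is available to show what this change does, so the expectation rests on compound 2 alone. The step of a 1.0-fold lower number from compound 2 to compound 3 (0.00 log units; within the scatter) is expected to stay within the usual scatter, with no direction read into it. Compound 3 is therefore estimated at 0.28 h in this assay, between 0.12 h and 0.65 h.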

Compound 3, half-life: 0.167 h
Beside the measured number, compound 3's estimate is 1.7-fold (0.22 log units) above it; measured number inside the range.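

Among these compounds, the new step gives the first reading of this position in this assay, with an open chain in place of a ring of the same heavy-atom count: a 1.7-fold lower number from compound 2 to compound 3 (0.23 log units; within the scatter). On this aromatic carbon, next to the ring nitrogen, the loss of the cyclopentyl ring thus does not carry the half-life beyond the usual scatter, though one step on one pair of compounds shows no more than that. Nothing shown bears on the cause of this step.

Carrying another group at this position and differing from compound 2 elsewhere as well, compound 1 gives > 1 h, a limit of the assay and not a number. From the compounds shown here alone, whether an amine or a carboxylic acid on this aromatic carbon would shift the half-life beyond the scatter remains open.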